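The source may report more compounds than this note shows. Statements on the series, on what has been measured and on what is new or still open speak of the compounds shown alone.

Measured so far in an assay for binding affinity to dual specificity mitogen-activated protein kinase kinase 4 (Homo sapiens), read by KINOMEscan, tested at 100 nM; a higher number here means a weaker effect of the compound at the concentration tested, a lower number a stronger effect:
- compound 1 `CCCS(=O)(=O)Nc1ccc(F)c(C(=O)c2n[nH]c3ncc(-c4ccccc4C)cc23)c1F`: 7%
- compound 2 `CCCS(=O)(=O)Nc1ccc(F)c(C(=O)c2n[nH]c3ncc(-c4ccc(OC)cc4)cc23)c1F`: 4.2%
- compound 3 `CCCS(=O)(=O)Nc1ccc(F)c(C(=O)c2n[nH]c3ncc(-c4cccc([N+](=O)[O-])c4)cc23)c1F`: 15%

Compound 3 carries the highest of the three numbers. Against its nearest neighbour the step is a number 8 percentage points higher from compound 1 to compound 3 (within the scatter), which stays inside the usual scatter, so compounds 1 and 3 cannot be separated. Against compound 2 the step is a number 10.8 percentage points higher from compound 2 to compound 3 (beyond the scatter), a modest change that does lie beyond the scatter. The third measured step, a number 2.8 percentage points lower from compound 1 to compound 2 (within the scatter), is again inside the scatter.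

Compound 4 `CCCS(=O)(=O)Nc1ccc(F)c(C(=O)c2n[nH]c3ncc(-c4ccc(S(N)(=O)=O)cc4)cc23)c1F` is the next member. It differs from compound 3 in one place: 4-sulfamoylphenyl in place of 3-nitrophenyl on an aromatic carbon. All three measured steps concern an exchange of the aryl group at this same position, and the largest of them was only modest. Going by the values given here, no measured compound carries the 4-sulfamoylphenyl group, so the series gives no direct precedent for it; what the steps show is that exchanges at this position have so far moved the number by little. The expected step from compound 3 is therefore a number 6 percentage points lower from compound 3 to compound 4 (within the scatter), most likely small and, if anything, toward the numbers of compounds 1 and 2. For compound 4 the estimated value in this assay is 9%, with a range from 2% to 25%.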

Compound 4, a percentage reported as activity, at one concentration (the size of the read-out at that concentration, not a potency): 0.25%
Beside the measured number, compound 4's estimate is 8.8 percentage points above it; the measured number lies below the stated range.
By their numbers in this assay, from the lowest: compounds 4, 2, 1 and 3 (each within the scatter of the next, the first and the last beyond it).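

In this assay, 4-sulfamoylphenyl gives a number 14.8 percentage points lower from compound 3 to compound 4 (beyond the scatter), so a second step at this position now lies beyond the scatter, and compound 3 stands apart from compounds 2 and 4 but not from compound 1. The other two steps, a number 4 percentage points lower from compound 2 to compound 4 (within the scatter) and a number 6.8 percentage points lower from compound 1 to compound 4 (within the scatter), stay inside the scatter, so an aryl group bearing a hydrogen-bond donor cannot be separated from 2-methylphenyl or 4-methoxyphenyl here. Nothing available explains these steps.

The step from compound 3 changes both the group and its place on the phenyl ring, so 3-sulfamoylphenyl and 4-nitrophenyl would be needed to separate those two changes. Also open, going by these compounds, is how a 4-carboxylic acid or a 4-aminomethyl group on the phenyl ring would read at this position.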